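Carboxy in place of hydroxymethyl: compound 3 to compound 4

The source may hold more compounds than are shown below. What is called first, only, known or untested is meant among the compounds shown, and "the series" means these compounds.

In a functional assay on DU-145 cells (Homo sapiens) for cytotoxicity, read by MTT assay (a lower number here means a stronger inhibitor, a higher number a weaker inhibitor), compound 1 (`COC(=O)C[C@H]1C[C@H](O)[C@@H](C)[C@@H](c2ccc(OC)cc2)N1`) gives 6500 nM and compound 3 (`COc1ccc([C@H]2N[C@@H](CCO)C[C@H](O)[C@H]2C)cc1`) gives 14800 nM, the higher of the two numbers available. Compound 2 (`COC(=O)C[C@H]1C[C@H](O)[C@H](C)[C@@H](c2ccccc2)N1`) is recorded as "not active" (no number reported), so it has no place on that scale.

The next compound to be read is compound 4 (`COc1ccc([C@H]2N[C@@H](CC(=O)O)C[C@H](O)[C@H]2C)cc1`), which differs from compound 3 as follows: carboxy in place of hydroxymethyl on a saturated chain carbon bound to a saturated ring carbon. This is carboxy in place of hydroxymethyl on a saturated chain carbon bound to a saturated ring carbon, or 2-hydroxyethyl to carboxymethyl when cut one bond further out.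

Going by the values given here, only one measured step changes this place: a 2.3-fold higher number from compound 1 to compound 3 (0.36 log units; beyond the scatter), a modest step on replacing methoxycarbonyl with hydroxymethyl. Among the compounds with values here, no measured step introduces carboxy, so that step is a rough guide to size only. A step no larger than that one is expected, toward a higher number, and a report without a number remains possible. The estimated change is a 1.5-fold higher number from compound 3 to compound 4 (0.17 log units; within the scatter). For compound 4 the expected value is 22000 nM, with an estimated range of 7000 nM to 60000 nM.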

Compound 4, half-maximal inhibitory concentration: 15700 nM
Compound 4: the middle estimate sits 1.4-fold (0.15 log units) above what was measured; low and high end bracket the measured number.
By their numbers in this assay, from the lowest: compound 1; then compounds 3 and 4 (each within the scatter of the next).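

In this assay, carboxy and hydroxymethyl on this saturated chain carbon are not separated (step: a 1.1-fold higher number from compound 3 to compound 4 (0.03 log units; within the scatter)), so exchanging one for the other leaves the reading within the scatter. Hydrogen in place of methyl on an oxygen next to a carbonyl group gives a modest step beyond the scatter (a 2.4-fold higher number from compound 1 to compound 4 (0.38 log units; beyond the scatter)), so among compounds 1, 3 and 4, two different replacements of methoxycarbonyl now end at about the same level, and compound 1 alone stands apart, where the earlier single step showed only one such replacement. Nothing on hand explains this shared level.

Still open, as far as these compounds go, is whether an ethyl ester would stay with compound 1 or join compounds 3 and 4. Also open, from the compounds shown here alone, is how an amide, an amine or a longer chain would read at this place.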